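A Trifluoromethyl Swap at the Assay Limit

The source may report more compounds than this note shows. Statements on the series, on what has been measured and on what is new or still open speak of the compounds shown alone.

In an ADME assay on MDCK cells (Canis lupus familiaris) for cytotoxicity, read by MTT assay, with a stated time of 72 h (on this read-out lower numbers stand for higher toxicity in this test and higher numbers for lower toxicity in this test), compound 1 (`C=C(CC(=O)Nc1ccc(F)cc1F)C(=O)O`) gives > 110000 nM as a limit and not a number. Compound 2 (`C=C(CC(=O)Nc1ccc(Cl)cc1F)C(=O)Nc1ccc(Cl)cc1F`) likewise gives a limit (> 110000 nM). Compound 3 (`C=C(CC(=O)Nc1ccc(Br)cc1F)C(=O)Nc1ccc(Br)cc1F`) also gives a limit (> 110000 nM). Compound 1 thus stands at the limit of > 110000 nM in this assay, at which 3 of the 3 values shown sit, with no exact value known. Compound 4 (`C=C(CC(=O)Nc1ccc(C(F)(F)F)cc1F)C(=O)O`) has trifluoromethyl in place of fluoro on an aromatic carbon. Among the measured compounds shown here, no step between measured compounds is available as a guide. In this assay the expected step (a number no higher from compound 1 to compound 4 (the limit leaves the size open)) is none beyond the usual scatter, with no direction expected. The estimated half-maximal cytotoxic concentration of compound 4 is 110000 nM (expected range 55000 nM to 220000 nM).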

Compound 4, half-maximal cytotoxic concentration: > 110000 nM
Compound 4: only a limit was reported; the forecaster's own chance of this, stated with the estimate: 80%; the middle value lies on the limit itself.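

No step can be read from compound 1 to compound 4, because both sit at a limit and not at a number: the limit of > 110000 nM in this assay, at which 4 of the 4 values shown sit. The compounds shown leave open the exact half-maximal cytotoxic concentration of each, and whether trifluoromethyl in place of fluoro shifts it at all.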